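A few compounds are considered here, and "the series" means these few. Any claim that something is new, unique, unknown or untested is made for them only; others in the source may bear on it.

Three measured compounds share one core and differ only in the aryl group attached to the amide carbonyl. Compound 1 `O=C(Nc1cccc(/C=C/C(=O)c2nc3ccccc3[nH]2)c1)c1cccc(Cl)c1` gives 3370 nM in a functional assay on 143B cells (Homo sapiens) for antiproliferative activity, read by MTT assay, with a stated time of 48 h; on this read-out lower numbers stand for stronger inhibition and higher numbers for weaker inhibition. Compound 2 `O=C(Nc1cccc(/C=C/C(=O)c2nc3ccccc3[nH]2)c1)c1cccc(Br)c1` gives 4620 nM in this assay. Compound 3 `Cc1ccccc1C(=O)Nc1cccc(/C=C/C(=O)c2nc3ccccc3[nH]2)c1` gives 8290 nM in this assay, the highest of the three numbers. The step of a 1.4-fold higher number from compound 1 to compound 2 (0.14 log units; within the scatter) lies within the scatter, whereas a 2.5-fold higher number from compound 1 to compound 3 (0.39 log units; beyond the scatter) is a modest step beyond it, and a 1.8-fold higher number from compound 2 to compound 3 (0.25 log units; within the scatter) stays within it. Compound 4 `O=C(Nc1cccc(/C=C/C(=O)c2nc3ccccc3[nH]2)c1)c1cccc(C(F)(F)F)c1` carries 3-(trifluoromethyl)phenyl in place of 2-methylphenyl on a carbonyl carbon. Among the measured compounds shown here, two measured steps bear on this change: a 2.5-fold higher number from compound 1 to compound 3 (0.39 log units; beyond the scatter) and a 1.8-fold higher number from compound 2 to compound 3 (0.25 log units; within the scatter), in which 2-methylphenyl entered in place of 3-chlorophenyl or 3-bromophenyl and the number rose. Compound 4 moves the other way, from 2-methylphenyl to 3-(trifluoromethyl)phenyl, so in this assay a lower number is expected, a step of about a 2.4-fold lower number from compound 3 to compound 4 (0.37 log units; beyond the scatter), bringing it near compounds 1 and 2. Compound 4 is therefore estimated at 3500 nM in this assay, with a range from 1500 nM to 8500 nM.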

Compound 4, half-maximal inhibitory concentration: 9570 nM
The estimate for compound 4 lay 2.7-fold (0.44 log units) below the measured number; the measured number lies above the stated range.
By their numbers in this assay, from the lowest: compounds 1, 2, 3 and 4 (each within the scatter of the next, the first and the last beyond it).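

Read in this assay, trifluoromethyl is not interchangeable with the halogens on this aromatic carbon: in place of chloro it gives a 2.8-fold higher number from compound 1 to compound 4 (0.45 log units; beyond the scatter) and in place of bromo it gives a 2.1-fold higher number from compound 2 to compound 4 (0.32 log units; beyond the scatter), both modest steps. Among the compounds shown here, in contrast, 3-(trifluoromethyl)phenyl in place of 2-methylphenyl on the carbonyl carbon gives a 1.2-fold higher number from compound 3 to compound 4 (0.06 log units; within the scatter), so the two groups cannot be told apart here, and the earlier compounds did not show that a larger group could leave the number at the level of 2-methylphenyl rather than of 3-chlorophenyl. Nothing available here explains this result.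

The compounds shown leave open whether fluoro, methoxy or an amine on the same aromatic carbon would fall with the chloro and bromo compounds or with compound 4. They also leave open whether an unsubstituted phenyl would match either level.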